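Shortening the chain in a cyanoguanidine series

A few compounds are considered here, and "the series" means these few. Any claim that something is new, unique, unknown or untested is made for them only; others in the source may bear on it.

Of the compounds shown here, two have been measured in a functional assay on the whole organism with Rattus norvegicus as the target, at a dose of 100 mg/kg; a lower number here means less inhibition, a higher number more inhibition at the dose given (going by the name of the read-out). Compound 1, `C/N=C(/NC#N)NCCCn1nc(-c2ccccc2)ccc1=O`, gives 40.5% in this assay. Compound 2, `C/N=C(/NC#N)NCCCCn1nc(-c2ccccc2)c(C)cc1=O`, gives 46.4% in this assay. Of the two numbers that of compound 2 is the higher, yet the gap between compound 2 and compound 1 lies within the usual scatter of repeated measurements, so the two cannot be told apart on these numbers alone.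

Compound 3, `C/N=C(/NC#N)NCCCn1nc(-c2ccccc2)c(C)cc1=O`, has not yet been measured. It differs from compound 2 in one place: a group of 7 heavy atoms (3 carbon, 4 nitrogen; no ring) in place of a group of 8 heavy atoms (4 carbon, 4 nitrogen; no ring), on a saturated chain carbon, three bonds along the chain from an aromatic nitrogen. The chain that joins the cyanoguanidine end to the core is thus made shorter by one saturated carbon, while the methyl on the core stays in place.

Among the measured compounds shown here, no step between two measured compounds shows what such a shortening does, since compound 1 and compound 2 differ in two places at once. For the measured compounds named here, with the two known numbers lying so close, the step from compound 2 to compound 3 in this assay is expected to be small, in no clear direction and within the scatter, a number 3.4 percentage points lower from compound 2 to compound 3 (within the scatter). Compound 3 is therefore estimated to give 43%, between 30% and 56%.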

Compound 3, a percentage reported as inhibition, in the whole organism at one dose (the size of the read-out at that dose, not a potency): 17.2%
For compound 3 the middle estimate is 25.8 percentage points above the measured one; measured number outside the range, below it.
By their numbers in this assay, from the lowest: compound 3; then compounds 1 and 2 (each within the scatter of the next).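

With the methyl on the core kept in place, removing one saturated carbon from the chain gives, in this assay, a number 29.2 percentage points lower from compound 2 to compound 3 (beyond the scatter) and so shows that this position responds to chain length. With the shorter chain kept in place, methyl in place of hydrogen on an aromatic carbon gives a number 23.3 percentage points lower from compound 1 to compound 3 (beyond the scatter) as well, which means that a change at either place can move the number beyond the scatter, even though compound 1 and compound 2, which differ at both places, could not be told apart. Nothing here explains why either change lowers the inhibition, so the reason for these two steps remains unknown.

The compounds shown leave open whether a chain longer than that of compound 2 would give more inhibition or less, and whether an ethyl group or a chlorine atom in place of the methyl would behave as the methyl does. They also leave open what shortening the chain does on a core without the methyl, so the size of the chain step is known only with the methyl present.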